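Compound 1 to compound 3: adding a methyl

The source may report more compounds than this note shows. Statements on the series, on what has been measured and on what is new or still open speak of the compounds shown alone.

- compound 1 `O=C(Nc1cccc(-c2nc3ccccc3s2)c1)c1cc([N+](=O)[O-])ccc1Cl`: > 27000 nM (a limit)
- compound 2 `O=C(Nc1cc(-c2nc3ccccc3s2)ccc1Cl)c1cc([N+](=O)[O-])ccc1Cl`: > 25000 nM (a limit)

In an ADME assay on HEK293 cells (Homo sapiens) for cytotoxicity, with a stated time of 72 h (on this read-out lower numbers stand for an effect already at smaller amounts and higher numbers for an effect only at larger amounts of compound), compound 1 stands only at a limit, > 27000 nM. Compound 3 `Cc1c(NC(=O)c2cc([N+](=O)[O-])ccc2Cl)cccc1-c1nc2ccccc2s1` differs from it by one change, methyl in place of hydrogen on an aromatic carbon, ortho to a 1,3-benzothiazol-2-yl group. For the measured compounds named here, the only measured step bearing on this is a step that the two limits leave unreadable from compound 1 to compound 2, with chloro in place of hydrogen on an aromatic carbon. Compound 2 also stands only at a limit, > 25000 nM. No step beyond the scatter is therefore expected in this assay, in either direction. The expected step is a step that the limit leaves unreadable from compound 1 to compound 3. Compound 3 is estimated at 28000 nM, with an expected range from 12000 nM to 60000 nM.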

Compound 3, half-maximal effective concentration: > 25000 nM
Compound 3 ended at the assay's limit; the forecaster's own chance of this, stated with the estimate: 80%; the middle value does not contradict the limit.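

In this assay compound 1 stands at a limit, > 27000 nM. Compound 3 also stands at a limit, > 25000 nM, so no step can be read between the two. The compounds shown leave open what effect, if any, the methyl has.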